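Lengthening the Butyl Chain of Compound 1 to Decyl

The source may report more compounds than this note shows. Statements on the series, on what has been measured and on what is new or still open speak of the compounds shown alone.

Compound 1 `CCCCc1ccc(-c2c(C)[nH]c(=O)n2C)cc1` gives the lowest number of the three measured compounds in a functional assay on the whole organism with Rattus norvegicus as the target (on this read-out higher numbers stand for an effect only at larger amounts of compound and lower numbers for an effect already at smaller amounts), with 0.1 mg/kg. Compound 2 `CCCCOc1ccc(-c2c(C)[nH]c(=O)n2C)cc1` follows with 0.3 mg/kg, and compound 3 `CCCCCCCCOc1ccc(-c2c(C)[nH]c(=O)n2C)cc1` stands furthest away with 30 mg/kg. The step of a 3.0-fold higher number from compound 1 to compound 2 (0.48 log units; beyond the scatter) is modest, whereas the step of a 100-fold higher number from compound 2 to compound 3 (2.00 log units; beyond the scatter) is large. Compound 4 `CCCCCCCCCCc1ccc(-c2c(C)[nH]c(=O)n2C)cc1` differs from compound 1 by hexyl in place of hydrogen on a saturated chain carbon, four bonds along the chain from an aromatic carbon. Among the compounds with values here, the only measured step that bears on this change is the chain lengthening a 100-fold higher number from compound 2 to compound 3 (2.00 log units; beyond the scatter), which with a shorter added chain already pushed the number far upward. A large rise in this assay is therefore expected for compound 4, a step of a 300-fold higher number from compound 1 to compound 4 (2.48 log units; beyond the scatter). Compound 4 is accordingly estimated at 30 mg/kg, within a range from 3 mg/kg to 300 mg/kg.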

Compound 4, minimum effective dose: 0.3 mg/kg
Compound 4: the middle estimate sits 100-fold (2.00 log units) above what was measured, and the stated range ends above it.
By their numbers in this assay, from the lowest: compound 1; then compounds 2 and 4 (each within the scatter of the next); then compound 3.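

In this assay, within the data shown here, adding hexyl at this saturated chain carbon costs only a 3.0-fold higher number from compound 1 to compound 4 (0.48 log units; beyond the scatter), so a long all-carbon chain is tolerated here far better than the earlier compounds suggested. The only earlier chain lengthening, with butyl added to the butoxy chain, gave a 100-fold higher number from compound 2 to compound 3 (2.00 log units; beyond the scatter), so that large rise does not carry over to this change. Nothing available explains the difference between the two lengthenings. The compounds shown leave open how the number runs through intermediate chains such as hexyl or octyl in place of butyl, and how an amine or a carboxylic acid on the chain would move it.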